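A few compounds are considered here, and "the series" means these few. Any claim that something is new, unique, unknown or untested is made for them only; others in the source may bear on it.

Among the measured compounds shown here, compound 2 `O=C(NCc1ccc(CNS(=O)(=O)c2ccc(F)cc2)cc1)c1ccc(F)cc1` gives the lowest of the two numbers so far: in an assay on MDA-MB-231 cells for binding affinity to C-X-C chemokine receptor type 4 (Homo sapiens), read by fluorescence and microscopy, with stated times of 10 min and 30 min (on this read-out lower numbers stand for an effect already at smaller amounts and higher numbers for an effect only at larger amounts of compound), compound 2 gives 1 nM, whereas compound 1 `O=C(NCc1ccc(CNS(=O)(=O)c2cccnc2)cc1)c1ccc(F)cc1` gives 1000 nM. Compound 3 `O=C(NCc1ccc(CNS(=O)(=O)c2cccc3ccccc23)cc1)c1ccc(F)cc1` differs from compound 2 by naphthalen-1-yl in place of 4-fluorophenyl on a sulfonyl sulfur. For the measured compounds named here, the only measured step at this position, a 1000-fold lower number from compound 1 to compound 2 (3.00 log units; beyond the scatter), shows that the group on the sulfonyl sulfur can shift the result greatly. Both groups involved here are aromatic rings of carbon only, so only a moderate move upward is expected, a 5.0-fold higher number from compound 2 to compound 3 (0.70 log units; beyond the scatter). Compound 3 is therefore expected to give about 5 nM, between 0.5 nM and 100 nM.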

Compound 3, effective concentration (reported as EC, without a stated level of effect): 1000 nM
Compound 3: the middle estimate sits 200-fold (2.30 log units) below what was measured, outside the stated range (above it).
By their numbers in this assay, from the lowest: compound 2; then compounds 1 and 3 (each within the scatter of the next).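

In this assay there is a 1000-fold higher number from compound 2 to compound 3 (3.00 log units; beyond the scatter), so an aromatic ring of carbon only does not by itself keep the number low at this place on the sulfonyl sulfur. There is also no change at the digits printed from compound 1 to compound 3 (within the scatter), so naphthalen-1-yl and pyridin-3-yl cannot be told apart here, and of the three groups only 4-fluorophenyl gives the low number. The data shown offer no explanation for this sharp dependence on the group.

Going by these compounds, it remains open whether a phenyl ring without fluorine, a methyl group or an amine on the sulfonyl sulfur would keep the low number.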